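A few compounds are considered here, and "the series" means these few. Any claim that something is new, unique, unknown or untested is made for them only; others in the source may bear on it.

Compound 1, `Cc1cc2c(cc1Cc1ccc(C(=O)NC[C@H]3CC[C@H](C(N)=O)CC3)o1)C(C)(C)CCC2(C)C`, gives 270 nM in an assay on isolated protein for binding affinity to Gonadotropin-releasing hormone receptor (Rattus norvegicus); on this read-out higher numbers stand for weaker inhibition and lower numbers for stronger inhibition.
Compound 2, `Cc1ccc(CNC(=O)c2ccc(Cc3cc4c(cc3C)C(C)(C)CCC4(C)C)o2)cc1`, gives 60 nM in this assay.
Compound 3, `Cc1cc2c(cc1Cc1ccc(C(=O)NCc3ccc(CN)cc3)o1)C(C)(C)CCC2(C)C`, gives 280 nM in this assay.

Compound 3 carries the highest of the three numbers, though its value and that of compound 1 sit within the scatter of one another, as a 1.0-fold higher number from compound 1 to compound 3 (0.02 log units; within the scatter) shows; only compound 2 stands clearly apart, by a 4.7-fold higher number from compound 2 to compound 3 (0.67 log units; beyond the scatter).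

Compound 4, `Cc1cc2c(cc1Cc1ccc(C(=O)NCc3ccccc3)o1)C(C)(C)CCC2(C)C`, differs from compound 3 in one place: hydrogen in place of aminomethyl on an aromatic carbon. Going by the values given here, two measured steps bear on this. The step of a 4.7-fold higher number from compound 2 to compound 3 (0.67 log units; beyond the scatter) shows that adding the amino group to the methyl of compound 2 raised the number by a modest but real amount. The step of a 4.5-fold lower number from compound 1 to compound 2 (0.65 log units; beyond the scatter) shows the 4-methylbenzyl of compound 2 giving a lower number than the 4-carbamoylcyclohexyl of compound 1. Nothing measured separates a plain benzyl from a 4-methylbenzyl, so the closest guide is the return from compound 3 toward compound 2.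

Compound 4 is therefore expected to show a modest lowering in this assay, roughly a 3.5-fold lower number from compound 3 to compound 4 (0.54 log units; beyond the scatter). The estimate for compound 4 is 80 nM, within a range of 30 nM to 250 nM.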

Compound 4, inhibition constant: 240 nM
Compound 4: middle estimate off by 3.0-fold (0.48 log units), on the low side; the measured number falls inside the stated range.
By their numbers in this assay, from the lowest: compound 2; then compounds 4, 1 and 3 (each within the scatter of the next).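

With hydrogen in place of aminomethyl on the aromatic carbon para to a large group, the read-out in this assay stays within the scatter (a 1.2-fold lower number from compound 3 to compound 4 (0.07 log units; within the scatter)), so the aminomethyl group and hydrogen cannot be told apart at this position. Methyl on the same carbon is what stands apart, since the step to hydrogen lies beyond the scatter (a 4.0-fold higher number from compound 2 to compound 4 (0.60 log units; beyond the scatter)), and of the three groups compared here, only methyl gives a clearly lower number. The phenyl of the plain benzyl amide also cannot be told apart from the 4-carbamoylcyclohexyl (a 1.1-fold lower number from compound 1 to compound 4 (0.05 log units; within the scatter)), which leaves compound 2 alone, clear of the three other compounds, whose numbers all lie within the scatter of one another.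

Nothing given here offers an explanation for why methyl alone separates from the other groups at this position. Still open, on these data alone, is whether an ethyl group, a chlorine atom or a methoxy group on this aromatic carbon would give a number like that of compound 2 or like that of compound 4.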